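Swapping the benzyl arm on the shared core of compound 2

The source may hold more compounds than are shown below. What is called first, only, known or untested is meant among the compounds shown, and "the series" means these compounds.

Three compounds share a core and differ only in the group carried on a saturated chain carbon bound to an amine nitrogen. Compound 1 `Cc1cc(C)cc(Cc2ccc3c(NCCCNCc4ccco4)ccnc3c2)c1` carries a furan-2-yl there and in an ADME assay on HepG2 cells (Homo sapiens) for cytotoxicity, read by luminescence, CellTiter-Glo and ATP content, with a stated time of 72 h (on this read-out lower numbers stand for an effect already at smaller amounts and higher numbers for an effect only at larger amounts of compound), compound 1 gives 6270 nM. Compound 2 `COc1cccc(CNCCCNc2ccnc3cc(Cc4cc(C)cc(C)c4)ccc23)c1O` carries a 2-hydroxy-3-methoxyphenyl and in this assay compound 2 gives 2680 nM, the second highest of the three numbers. Compound 3 `COc1ccc(F)cc1CNCCCNc1ccnc2cc(Cc3cc(C)cc(C)c3)ccc12` carries a 5-fluoro-2-methoxyphenyl and in this assay compound 3 gives 940 nM. The measured steps are a 2.3-fold lower number from compound 1 to compound 2 (0.37 log units; beyond the scatter), a 6.7-fold lower number from compound 1 to compound 3 (0.82 log units; beyond the scatter) and a 2.9-fold lower number from compound 2 to compound 3 (0.46 log units; beyond the scatter); every one of them changes the group on that chain carbon and nothing else.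

Compound 4 `COc1cccc(CNCCCNc2ccnc3cc(-c4ccccc4)ccc23)c1O` is different in kind. Relative to compound 2 it keeps the 2-hydroxy-3-methoxyphenyl arm and instead alters the other end of the core: phenyl in place of 3,5-dimethylbenzyl on an aromatic carbon. For the measured compounds named here, no measured step touches this part of the molecule, so the three steps above give no guide to its size or direction. With nothing to build on, the plainest expectation for compound 4 in this assay is a number close to that of compound 2, and the expected step is a 1.3-fold higher number from compound 2 to compound 4 (0.12 log units; within the scatter), within the scatter. The estimate for compound 4 is therefore 3500 nM, with a wide range from 1200 nM to 10000 nM.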

Compound 4, half-maximal effective concentration: 3210 nM
Compound 4: middle estimate off by 1.1-fold (0.04 log units), on the high side; the measured number falls inside the stated range.
By their numbers in this assay, from the lowest: compound 3; then compounds 2, 4 and 1 (each within the scatter of the next, the first and the last beyond it).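

In this assay, replacing the 3,5-dimethylbenzyl of 9 heavy atoms with a phenyl of 6 heavy atoms on this aromatic carbon gives a 1.2-fold higher number from compound 2 to compound 4 (0.08 log units; within the scatter), so this first change at that end of the core makes no difference that can be told from assay noise. The contrast lies with the arm on the saturated chain carbon, where each of the three measured swaps moved the number beyond the scatter, for example a 2.9-fold lower number from compound 2 to compound 3 (0.46 log units; beyond the scatter), whereas this change, made with the 2-hydroxy-3-methoxyphenyl arm held fixed, did not. Nothing available explains why the cell read-out stays level across this swap, and no supporting data bear on it.

Whether phenyl would behave the same way alongside the furan-2-yl or 5-fluoro-2-methoxyphenyl arm remains open, as the compounds shown test this swap with one arm only. Also open, from the compounds shown here alone, is what a different group on this aromatic carbon, such as a carboxylic acid or an amine, would do to the number, given that both groups compared here are hydrocarbon groups with a six-membered aromatic ring of carbon only.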